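A few compounds are considered here, and "the series" means these few. Any claim that something is new, unique, unknown or untested is made for them only; others in the source may bear on it.

Compound 1 `Cc1nc(C(=O)Nc2ccc(Cl)c(-c3nnc4c(Cl)cccn34)c2)cs1`: in a functional assay on U-251 cells (Homo sapiens) for antiproliferative activity, read by MTT assay, with a stated time of 72 h (on this read-out higher numbers stand for weaker inhibition and lower numbers for stronger inhibition), compound 1 gives 74300 nM.
Compound 2 `O=C(Nc1ccc(Cl)c(-c2nnc3c(Cl)cccn23)c1)c1c(F)cccc1Cl`: in this assay compound 2 reaches only a limit, > 100000 nM.
Compound 3 `CS(=O)(=O)c1cccc(C(=O)Nc2ccc(Cl)c(-c3nnc4c(Cl)cccn34)c2)c1`: in this assay compound 3 reaches only a limit, > 100000 nM.

Within the data shown here, compound 1 thus stands as the only measured number in the set; the two other values are limits, as the limit of > 100000 nM in this assay, at which 2 of the 3 values shown sit, records. Compound 4 `O=C(Nc1ccc(Cl)c(-c2nnc3c(Cl)cccn23)c1)c1ccccn1` differs from compound 1 in one place: pyridin-2-yl in place of 2-methyl-1,3-thiazol-4-yl on a carbonyl carbon. Among the measured compounds shown here, the steps that bear on this change are an at least 1.3-fold higher number from compound 1 to compound 2 (0.12 log units; that floor lies within the scatter) and an at least 1.3-fold higher number from compound 1 to compound 3 (0.12 log units; that floor lies within the scatter), both replacements at the same carbonyl carbon; a step that the two limits leave unreadable from compound 2 to compound 3. Every change seen at this position has left the number at or beyond the limit, so compound 4 is expected to stay weak in this assay, with a step of a 1.2-fold higher number from compound 1 to compound 4 (0.08 log units; within the scatter) that may not exceed the scatter. The estimate for compound 4 is 90000 nM, within 30000 nM to 250000 nM.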

Compound 4, half-maximal inhibitory concentration: 79000 nM
Beside the measured number, compound 4's estimate is 1.1-fold (0.06 log units) above it; low and high end bracket the measured number.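

In this assay, pyridin-2-yl in place of 2-methyl-1,3-thiazol-4-yl on the carbonyl carbon gives a 1.1-fold higher number from compound 1 to compound 4 (0.03 log units; within the scatter), so this position now holds a second measured number and the two groups cannot be told apart. Against the other two compounds, the change reads an at least 1.2-fold lower number from compound 3 to compound 4 (0.10 log units; that floor lies within the scatter) and an at least 1.2-fold lower number from compound 2 to compound 4 (0.10 log units; that floor lies within the scatter), and neither floor establishes a real gain. The values of compound 2 and compound 3 remain limits of the assay, not numbers: the limit of > 100000 nM in this assay, at which 2 of the 4 values shown sit.

As far as these compounds go, whether any group on this carbonyl carbon can bring the number well below these values stays open. A carboxylic acid or an amine such as morpholine at this place would test that.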